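One more chain carbon on compound 1

The compounds below may be only part of what the source reports. "The series", "measured", "known", "first", "only" and "open" are said of these compounds alone.

Measured so far:
Compound 1 `C#CCCCOc1ccc2oc(=O)c(C(=O)OC)cc2c1` — 1440 nM
Compound 2 `C#CCCCOc1cccc2cc(C(=O)OC)c(=O)oc12` — > 10000 nM

In an assay on cells for inhibition of Amine oxidase [flavin-containing] B (Homo sapiens), read by Amplex Red, with stated times of 30 min and 45 min (a higher number here means a weaker inhibitor, a lower number a stronger inhibitor), compound 1 gives 1440 nM. For compound 2 the result is a limit rather than a number, > 10000 nM. Among the measured compounds shown here, compound 1 thus stands as the only numeric value in this assay; the other result is the limit of > 10000 nM in this assay, at which 1 of the 2 values shown sits. For the measured compounds named here, the two compounds carry the same chain on different positions of the shared core, and no step between measured compounds that differ in a single place exists, so the measured data give no guide to the size of a chain change.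

Compound 3 `C#CCCCCOc1ccc2oc(=O)c(C(=O)OC)cc2c1` differs from compound 1 by propargyl in place of ethynyl on a saturated chain carbon, three bonds along the chain from an oxygen on an aromatic ring. Going by the values given here, with no measured step to draw on, the expected change in this assay from compound 1 to compound 3 is small, not beyond the scatter, and its direction is open, so the estimate is a 1.0-fold higher number from compound 1 to compound 3 (0.02 log units; within the scatter). Compound 3 is therefore expected to give 1500 nM, within a range from 500 nM to 4500 nM.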

Compound 3, half-maximal inhibitory concentration: 123 nM
The estimate for compound 3 lay 12-fold (1.09 log units) above the measured number; the measured number lies below the stated range.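

In this assay, the change of propargyl in place of ethynyl on a saturated chain carbon, three bonds along the chain from an oxygen on an aromatic ring, gives a 12-fold lower number from compound 1 to compound 3 (1.07 log units; beyond the scatter), and this is the only step in a single place among the compounds shown. Compound 1 and compound 2 carry the same chain at different places on the shared core, so they gave no measure of what the length of the chain does; the step now shows that, with the core and its attachment unchanged, going from pent-4-yn-1-yl to hex-5-yn-1-yl alone moves the number by a large amount, and towards a stronger inhibitor. Nothing measured among these compounds accounts for why this change has so large an effect.

Going by these compounds, how a longer chain such as hept-6-yn-1-yl would read stays open, and a single step cannot say whether the number would go on falling, level off or turn back. Also open, on these data alone, is what the end of the chain contributes, for instance whether a plain hexyl chain or a nitrile in place of the terminal triple bond would read like compound 3.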